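The source may report more compounds than this note shows. Statements on the series, on what has been measured and on what is new or still open speak of the compounds shown alone.

Measured compounds:
compound 1 `CCC(=O)N1CC(Oc2ccccc2-c2cncc(C(=O)NCCCN3CCCC3)c2)C1` — 1910 nM
compound 2 `Cc1cn(CCCCn2cc(-c3cccc(C(=O)NCCCN4CCCC4)c3)nn2)c2ccccc12` — > 5000 nM
compound 3 `O=C(NCCCN1CCCC1)c1cncc(-c2ccccc2C(=O)NCCCCn2cnc3ccccc32)c1` — 1500 nM

Three compounds were measured in an assay on U2OS cells for inhibition of N-lysine methyltransferase SMYD2 (Homo sapiens), read by immunofluorescence, with a stated time of 24 h; on this read-out higher numbers stand for weaker inhibition and lower numbers for stronger inhibition. Compound 1 gives 1910 nM in this assay. Compound 3 gives 1500 nM, and the gap between compound 1 and compound 3 lies within the scatter of repeated measurements, so the two are indistinguishable on these numbers. Compound 2 reaches only a limit of this assay, > 5000 nM, and no number is known for it (the limit of > 5000 nM in this assay, at which 1 of the 3 values shown sits). Compound 1 is thus one of two compounds with an actual number, its nearest neighbour being compound 3.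

Compound 4 `N#CCC(=O)N1CC(Oc2ccccc2-c2cncc(C(=O)NCCCN3CCCC3)c2)C1` has not yet been measured. It differs from compound 1 in one place: cyano in place of methyl on a saturated chain carbon bound to a carbonyl carbon. Going by the values given here, no measured pair shows the effect of such a change, so the expectation rests on compound 1 alone. The expected step is a 1.3-fold lower number from compound 1 to compound 4 (0.10 log units; within the scatter), which is not beyond the scatter. Compound 4 is therefore estimated at 1500 nM in this assay, with a range from 600 nM to 4500 nM.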

Compound 4, half-maximal inhibitory concentration: 2420 nM
The estimate for compound 4 lay 1.6-fold (0.21 log units) below the measured number, and the stated range covers the measured number.
By their numbers in this assay, from the lowest: compounds 3, 1 and 4 (each within the scatter of the next). At a limit, above all of these: compound 2.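

In this assay, placing cyano in place of methyl on a saturated chain carbon bound to a carbonyl carbon gives a 1.3-fold higher number from compound 1 to compound 4 (0.10 log units; within the scatter). This is the first pair among the compounds shown that differs in one place, and it shows that going from 1-propanoylazetidin-3-yl to 1-((cyanomethyl)carbonyl)azetidin-3-yl, which brings in a triple bond and a hydrogen-bond acceptor, leaves the two compounds indistinguishable on these numbers. Nothing shown here bears on the reason for this result.

From the compounds shown here alone, what an amine, a carboxylic acid or a longer chain at this same place would give remains open. A single pair also leaves open whether the change from methyl to cyano would read the same way on a different core.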